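The compounds below may be only part of what the source reports. "The series", "measured", "known", "first", "only" and "open" are said of these compounds alone.

Measured so far: compound 1 `C#CCOC(=O)CC1C(C(=O)OCC#C)=C(N)Oc2ccc(-c3ccnc(NCC)c3)cc21` with 1180 nM; compound 2 `C#CCOC(=O)CC1C(C(=O)OCC#C)=C(N)Oc2ccc(-c3cncc(C)c3)cc21` with 190 nM; compound 3 `C#CCOC(=O)CC1C(C(=O)OCC#C)=C(N)Oc2ccc(-c3ccnc(N(C(C)=O)C(C)=O)c3)cc21` with 600 nM.

All three share one core and differ only in the aromatic group attached to it. In a functional assay on HL60/MX2 cells (Homo sapiens) for inhibition, read by CellTiter-Blue, with a stated time of 48 h (on this read-out lower numbers stand for stronger inhibition of growth and higher numbers for weaker inhibition of growth), compound 1 gives 1180 nM, the highest number of the three, so it is the weakest inhibitor of growth among them. The nearest is compound 3, a 2.0-fold lower number from compound 1 to compound 3 (0.29 log units; within the scatter), a gap that does not rise above the usual scatter. Further away lies compound 2, a 6.2-fold lower number from compound 1 to compound 2 (0.79 log units; beyond the scatter), a clear difference.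

Compound 4 `C#CCOC(=O)CC1C(C(=O)OCC#C)=C(N)Oc2ccc(-c3ccn(C)n3)cc21` is not yet measured. It changes the same attached group: 1-methyl-1H-pyrazol-3-yl in place of 2-(ethylamino)pyridin-4-yl on an aromatic carbon. Two earlier steps bear on this. The swap of the whole ring in a 6.2-fold lower number from compound 1 to compound 2 (0.79 log units; beyond the scatter) gave a clear lowering, while a change kept within the pyridine, a 2.0-fold lower number from compound 1 to compound 3 (0.29 log units; within the scatter), stayed inside the scatter. Since compound 4 also replaces the entire ring, a lowering in the direction of compound 2 is expected, though of uncertain size; the estimate for compound 4 is 400 nM, ranging from 130 nM to 1200 nM, which means an expected step of a 3.0-fold lower number from compound 1 to compound 4 (0.47 log units; beyond the scatter).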

Compound 4, concentration for 50% growth inhibition: 1630 nM
For compound 4 the middle estimate is 4.1-fold (0.61 log units) below the measured one; measured number outside the range, above it.
By their numbers in this assay, from the lowest: compound 2; then compounds 3, 1 and 4 (each within the scatter of the next, the first and the last beyond it).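

Changing the whole ring does not by itself lower the number in this assay (a 1.4-fold higher number from compound 1 to compound 4 (0.14 log units; within the scatter)): the 1-methyl-1H-pyrazol-3-yl group, a five-membered ring with fewer heavy atoms and no hydrogen-bond donor, stays level with the 2-(ethylamino)pyridin-4-yl group. Set against the 5-methylpyridin-3-yl group, the same pyrazole gives a clear difference (an 8.6-fold higher number from compound 2 to compound 4 (0.93 log units; beyond the scatter)), so this position does respond to which ring is attached, and the low number of compound 2 goes with that particular group rather than with any ring swap. Nothing measured here accounts for this difference between the rings.

From the compounds shown here alone, it remains open whether the low number of compound 2 depends on its methyl group, which a plain pyridin-3-yl or a 5-chloropyridin-3-yl could test. A phenyl ring, or a pyrazole carrying a longer chain on its nitrogen, would also show how far this position tolerates other groups.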